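Compound 3 to compound 4: methylsulfonyl for methylsulfanyl

The source may hold more compounds than are shown below. What is called first, only, known or untested is meant among the compounds shown, and "the series" means these compounds.

In a functional assay on the whole organism for antagonist activity, with Mus musculus as the target (a higher number here means that more compound is needed for the effect, a lower number that less compound is needed), compound 1 (`Cn1c(-c2cccc3ccccc23)nnc1S(C)(=O)=O`) reports only a limit (> 200 mg/kg). Compound 2 (`Cn1nc(-c2ccccc2)nc1S(C)(=O)=O`) also reports only a limit (> 200 mg/kg). Compound 3 (`CSc1nc(-c2ccccc2)n(C)n1`) likewise reports only a limit (> 100 mg/kg), so no exact value places it within the series. Compound 4 (`Cn1nc(S(C)(=O)=O)nc1-c1ccccc1`) carries methylsulfonyl in place of methylsulfanyl on an aromatic carbon. Going by the values given here, no measured step between two compounds gives the size of this change, and the limits give no direction. No step beyond the scatter is expected, and the estimated step is small (a number no higher from compound 3 to compound 4 (the limit leaves the size open)). This expectation is weakly founded. For compound 4 the estimated dose is 100 mg/kg with an expected range from 15 mg/kg to 300 mg/kg in this assay.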

Compound 4, dose for half-maximal effect: > 200 mg/kg
Compound 4 was reported as a limit; the forecaster's own chance of this, stated with the estimate: 55%; middle value at least 2.0-fold (0.30 log units) away from the limit.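

Compound 3 and compound 4 are both reported only as limits, so no step can be read between them. The compounds shown leave open whether methylsulfonyl in place of methylsulfanyl changes the dose at all in this assay.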